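Three measured ureas and one estimated relative

The compounds below may be only part of what the source reports. "The series", "measured", "known", "first", "only" and "open" are said of these compounds alone.

Compound 2 `CNC(=O)CCc1ccc(NC(=O)Nc2ccc(Cl)c(C(F)(F)F)c2)cc1` carries a 2-(methylcarbamoyl)ethyl group on the shared core. In a functional assay on HT-29 cells (Homo sapiens) for inhibition, read by MTT assay, with a stated time of 120 h (on this read-out lower numbers stand for stronger inhibition and higher numbers for weaker inhibition), compound 2 gives 20600 nM. Compound 1 `CC(NC(=O)CCc1ccc(NC(=O)Nc2ccc(Cl)c(C(F)(F)F)c2)cc1)c1ccccc1` differs from it only in that (1-phenylethyl in place of methyl on an amide-type nitrogen). In this assay compound 1 gives 26500 nM, so this change made a 1.3-fold higher number from compound 2 to compound 1 (0.11 log units; within the scatter).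

Compound 3 `CNC(=O)/C=C(\C)c1ccc(NC(=O)Nc2ccc(Cl)c(C(F)(F)F)c2)cc1` has a different core: 1-methyl-2-(methylcarbamoyl)ethenyl in place of 2-(methylcarbamoyl)ethyl on an aromatic carbon. In this assay compound 3 gives > 50000 nM, which is a limit of the assay and not a number. Compound 3 therefore sits at the limit of > 50000 nM in this assay, at which 1 of the 3 values shown sits. The core change gave an at least 2.4-fold higher number from compound 2 to compound 3 (0.38 log units; beyond the scatter).

Compound 4 `C/C(=C\C(=O)NC(C)c1ccccc1)c1ccc(NC(=O)Nc2ccc(Cl)c(C(F)(F)F)c2)cc1` has not yet been measured. It differs from compound 3 in that (1-phenylethyl in place of methyl on an amide-type nitrogen). Among the measured compounds shown here, this is the same change as the one from compound 2 to compound 1, made at the same place. Because that change gave a 1.3-fold higher number from compound 2 to compound 1 (0.11 log units; within the scatter), the expected step for compound 4 is of similar size, a step that the limit leaves unreadable from compound 3 to compound 4. Compound 3 already sits at the limit of > 50000 nM in this assay, at which 1 of the 3 values shown sits, so compound 4 is expected to sit at or beyond that limit as well. The estimate for compound 4 in this assay is 70000 nM. The expected range for compound 4 runs from 30000 nM to 200000 nM. The assay is expected to report only a limit for compound 4 in most repeats.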

Compound 4, half-maximal inhibitory concentration: > 50000 nM
Compound 4: only a limit was reported; the forecaster's own chance of this, stated with the estimate: 75%; the middle value is on the limit's open side.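

In this assay compound 4 gives > 50000 nM, which is a limit of the assay and not a number. Compound 3 stands at a limit too, so no step from one to the other can be read: the limit of > 50000 nM in this assay, at which 2 of the 4 values shown sit.

The compounds shown leave open whether 1-phenylethyl in place of methyl on the amide-type nitrogen makes any difference on the core of compound 3.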